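A few compounds are considered here, and "the series" means these few. Any claim that something is new, unique, unknown or untested is made for them only; others in the source may bear on it.

Measured so far in an ADME assay on H9c2 cells (Rattus norvegicus) for cytotoxicity, read by resazurin assay, with a stated time of 72 h; on this read-out higher numbers stand for lower toxicity in this test and lower numbers for higher toxicity in this test:

- compound 1 `C/C(=N\Nc1nc(C)cs1)c1ccc(Cl)c(Cl)c1`: 26100 nM
- compound 2 `C/C(=N\Nc1nc(-c2ccccn2)cs1)c1ccc(Cl)c(Cl)c1`: 10200 nM
- compound 3 `C/C(=N\Nc1nc(-c2ccc(Cl)c(Cl)c2)cs1)c1ccc(Cl)c(Cl)c1`: > 50000 nM

Compound 3 gives > 50000 nM in this assay, which is a limit of the assay and not a number. Compound 4 `C/C(=N\Nc1nc(-c2ccc(Br)cc2)cs1)c1ccc(Cl)c(Cl)c1` carries 4-bromophenyl in place of 3,4-dichlorophenyl on an aromatic carbon.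

Two measured steps at this same place bear on the change. One is a 2.6-fold lower number from compound 1 to compound 2 (0.41 log units; beyond the scatter), with pyridin-2-yl entering. The other is an at least 4.9-fold higher number from compound 2 to compound 3 (0.69 log units; beyond the scatter), with 3,4-dichlorophenyl entering. A third, an at least 1.9-fold higher number from compound 1 to compound 3 (0.28 log units; that floor lies within the scatter), gives only a floor that lies within the scatter.

Going by the values given here, no measured step swaps one carbon-only aromatic ring for another, so the guide is indirect. Compound 4 keeps such a ring, and the lower number at this place came with pyridin-2-yl in a 2.6-fold lower number from compound 1 to compound 2 (0.41 log units; beyond the scatter). Only a small move toward a lower number is therefore expected, as an at least 1.2-fold lower number from compound 3 to compound 4 (0.09 log units; that floor lies within the scatter). Compound 4 is estimated at 40000 nM, with an expected range of 17000 nM to 50000 nM.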

Compound 4, half-maximal cytotoxic concentration: > 50000 nM
Compound 4 was reported as a limit (the forecaster's own chance of this, stated with the estimate: 45%); middle value at least 1.2-fold (0.09 log units) from the limit.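

In this assay compound 4 gives > 50000 nM, which is a limit of the assay and not a number. At this position, a second ring of carbon only, 4-bromophenyl in place of 3,4-dichlorophenyl, also reaches that limit, giving an at least 4.9-fold higher number from compound 2 to compound 4 (0.69 log units; beyond the scatter), and an at least 1.9-fold higher number from compound 1 to compound 4 (0.28 log units; that floor lies within the scatter). The step between compound 3 and compound 4 cannot be read, and this assay does not separate the two rings: the limit of > 50000 nM in this assay, at which 2 of the 4 values shown sit.

As far as these compounds go, how far the true values of compound 3 and compound 4 lie past the limit stays open. Also open, from the compounds shown here alone, is whether an unsubstituted phenyl ring, an amine or a carboxylic acid at this position would stay at the limit or come down toward the value of compound 2.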